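This account rests on a few compounds, and the source may have more. Where it says the series, first, only, none or still open, it means among the compounds named here.

Working notes on the pyrazoline series in a functional assay on the whole organism (strain albino) for inhibition, with Rattus norvegicus as the target, read by paw edema, with stated times of 30 min and 3 h, at a dose of 100 mg/kg by the oral route; a lower number here means less inhibition, a higher number more inhibition at the dose given (going by the name of the read-out).

Three compounds have numbers. Compound 1, `COc1ccc(C2=NNC(c3c(Cl)cccc3Cl)C2)cc1`, gives 60% in this assay. Compound 2, `COc1ccc(C2CC(c3ccc(OC)c(OC)c3)=NN2C(=O)CBr)c(OC)c1`, gives 71%. Compound 3, `COc1ccc(C2=NN(C(=O)C(C)O[N+](=O)[O-])C(c3ccco3)C2)cc1OC`, gives 42%. On these three numbers compound 2 stands highest: its gap to compound 1 lies beyond the usual scatter, and its gap to compound 3 lies further beyond it. Going by the values given here, no pair among the three differs in only one place, so no single step can be read from them.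

Compound 4, `COc1ccc(C2CC(c3ccc(OC)c(OC)c3)=NN2C(=O)CNc2ccc(/C(C)=N/O)cc2)c(OC)c1`, has not been measured. It differs from compound 2 by a group of 11 heavy atoms (8 carbon, 2 nitrogen, 1 oxygen; one six-membered aromatic ring of carbon only) in place of one bromine atom, on a saturated chain carbon bound to a carbonyl carbon. With no measured step of this kind in the set, the direction is open; the expectation is a step that stays within the scatter or falls slightly below it, since the core and the two aryl groups of compound 2 remain in place. Compound 4 is therefore expected at 62%, with a range from 48% to 76%. The step this expectation implies is a number 9 percentage points lower from compound 2 to compound 4 (within the scatter), an estimated small downward move.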

Compound 4, a percentage reported as inhibition, in the whole organism at one dose (the size of the read-out at that dose, not a potency): 46%
For compound 4 the middle estimate is 16 percentage points above the measured one; the whole stated range lies above it.
By their numbers in this assay, from the lowest: compounds 3 and 4 (each within the scatter of the next); then compound 1; then compound 2.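

In this assay, going by these compounds alone, the saturated chain carbon bound to a carbonyl carbon now gives the first readable step: replacing bromo with a group of 11 heavy atoms that carries a six-membered aromatic ring of carbon only gives a number 25 percentage points lower from compound 2 to compound 4 (beyond the scatter) at the dose tested. This position is therefore not indifferent to this exchange, although the larger group does not abolish the read-out, with compound 4 still at 46% in this measurement. No measured data bear on why the number falls, and this single step cannot be divided among the parts of the entering group.

On these data alone, whether a simple amine such as dimethylamino, or a short alkyl chain, in place of bromo would hold the number of compound 2 remains open. Also open, as far as these compounds go, is whether a chlorine atom at this carbon would give a step of similar size.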